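Swapping the Methoxyphenyl Arm: Effect on Cell Toxicity

The source may hold more compounds than are shown below. What is called first, only, known or untested is meant among the compounds shown, and "the series" means these compounds.

Compound 1 `COc1cc(C(C2=C(O)C(=O)c3ccccc3C2=O)c2c[nH]c3ccc(Br)cc23)cc(OC)c1OC`: 36300 nM
Compound 2 `COc1ccccc1C(C1=C(O)C(=O)c2ccccc2C1=O)c1c[nH]c2ccccc12`: > 200000 nM
Compound 3 `O=C1C(O)=C(C(c2ccccc2)c2c(-c3ccccc3)[nH]c3ccccc23)C(=O)c2ccccc21`: 26400 nM

Three compounds share a core and differ in the groups hung on it. In a toxicity assay (Homo sapiens) for cytotoxicity, read by MTT assay, with a stated time of 48 h (a higher number here means a weaker inhibitor, a lower number a stronger inhibitor), compound 1 gives 36300 nM and compound 3 gives 26400 nM. For compound 2 the reading is only a limit, > 200000 nM, and the piece of evidence here is the limit of > 200000 nM in this assay, at which 1 of the 3 values shown sits. Compound 4 `COc1ccc(C(C2=C(O)C(=O)c3ccccc3C2=O)c2c[nH]c3ccccc23)cc1Br` is not yet measured; it differs from compound 2 by 3-bromo-4-methoxyphenyl in place of 2-methoxyphenyl on a saturated chain carbon bound to an aromatic carbon and a double-bonded ring carbon. Going by the values given here, no step between measured compounds is available, so the size of this change is not known. Compound 4 is expected to give 70000 nM, within 25000 nM to 200000 nM. The expected step of an at least 2.8-fold lower number from compound 2 to compound 4 (0.45 log units; beyond the scatter) is toward a stronger inhibitor, but it may well stay within the scatter.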

Compound 4, half-maximal inhibitory concentration: 25200 nM
For compound 4 the middle estimate is 2.8-fold (0.44 log units) above the measured one, within the range that was stated.
By their numbers in this assay, from the lowest: compounds 4, 3 and 1 (each within the scatter of the next). At a limit, above all of these: compound 2.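

In this assay, going by these compounds alone, putting 3-bromo-4-methoxyphenyl in place of 2-methoxyphenyl gives an at least 7.9-fold lower number from compound 2 to compound 4 (0.89 log units; beyond the scatter), the first comparison here of compounds differing in one place, and it shows that the group at this position can change the reading beyond the scatter. Compound 2 sets one end of this step, and its reading is a limit of the assay, not a number: the limit of > 200000 nM in this assay, at which 1 of the 4 values shown sits.

Still open, on these data alone, is whether the bromine or the new methoxy placement accounts for the step, which a 3-bromophenyl or 4-methoxyphenyl arm could separate. As far as these compounds go, how an amine or a carboxylic acid on this arm would read also remains open.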